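Methyl in Place of Cyclopropyl on the Ring Nitrogen Chain

This account rests on a few compounds, and the source may have more. Where it says the series, first, only, none or still open, it means among the compounds named here.

Of the compounds shown here, three have been measured in a functional assay on the whole organism for antagonist activity, with Mus musculus as the target; on this read-out lower numbers stand for an effect already at smaller amounts and higher numbers for an effect only at larger amounts of compound. Compound 1 `CCCCCCN1CCC(C(=O)Nc2cc(Cl)c(N)cc2OC)CC1` gives > 10 mg/kg, a limit of the assay. Compound 2 `COc1cc(N)c(Cl)cc1NC(=O)C1CCN(CC2CC2)CC1` gives > 10 mg/kg, a limit of the assay. Compound 3 `CCC(CC)CN1CCC(C(=O)Nc2cc(Cl)c(N)cc2OC)CC1` gives > 10 mg/kg, a limit of the assay.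

Compound 2 therefore stands only at the limit, with no number of its own; all three measured values sit there, which is the limit of > 10 mg/kg in this assay, at which 3 of the 3 values shown sit. The step from compound 1 to compound 2 is a step that the two limits leave unreadable from compound 1 to compound 2, the step from compound 1 to compound 3 is a step that the two limits leave unreadable from compound 1 to compound 3, and the step from compound 2 to compound 3 is a step that the two limits leave unreadable from compound 2 to compound 3. None of them gives a readable size.

Compound 4 `CCN1CCC(C(=O)Nc2cc(Cl)c(N)cc2OC)CC1` differs from compound 2 by methyl in place of cyclopropyl on a saturated chain carbon bound to an amine nitrogen in a ring. Among the compounds with values here, the steps that bear on this change are the three unreadable ones among compounds 1, 2 and 3, and they give no size and no direction to carry over. Compound 4 is expected to give 15 mg/kg, within 5 mg/kg to 45 mg/kg, most likely again only a limit. The step from compound 2 to compound 4 is thus expected to be a step that the limit leaves unreadable from compound 2 to compound 4, nothing beyond the scatter.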

Compound 4, dose for half-maximal effect: > 10 mg/kg
Compound 4: no number, only a limit; the forecaster's own chance of this, stated with the estimate: 75%; the middle value is on the limit's open side.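

In this assay compound 4 gives > 10 mg/kg as a limit and not a number, so its steps to compound 1, compound 2 and compound 3 cannot be read. The compounds shown leave open whether any of these chains on the ring nitrogen changes the dose at all, with every value at one limit: the limit of > 10 mg/kg in this assay, at which 4 of the 4 values shown sit.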